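Swapping a two-nitrogen ring for a three-carbon ring

The compounds below may be only part of what the source reports. "The series", "measured", "known", "first", "only" and "open" are said of these compounds alone.

Measured compounds:
- compound 1, `Cc1cc(C(=O)O)ccc1CN1CCC[C@H](O[C@H](CO)c2cc(Cl)cc(Cl)c2)[C@@H]1c1cccnc1`: 47000 nM
- compound 2, `O=C(O)c1ccc2nc(CN3CCC[C@H](O[C@H](CO)c4cc(Cl)cc(Cl)c4)[C@@H]3c3ccccc3)[nH]c2c1`: 380 nM
- compound 3, `Cc1cc(C(=O)O)ccc1CN1CCC[C@@]2(C[C@@H](c3ccccc3)CO2)[C@@H]1c1ccccc1`: 43000 nM

All three were tested in an assay on isolated protein for activation of cGMP-dependent protein kinase 1 (Homo sapiens), read by ADP-Glo, with stated times of 30 min and 2 h, in the presence of a further agent that is not named here; a higher number here means that more compound is needed for the effect, a lower number that less compound is needed. Compound 2 stands lowest of the three numbers, so it needs the least compound; compound 3 lies a long way above it, and compound 1 a little further still, both gaps beyond the usual scatter. Among the compounds with values here, compound 1 and compound 3 each differ from compound 2 in more than one place, so no single step between measured compounds is available.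

Compound 4, `O=C(O)c1ccc(CN2CCC[C@H](O[C@H](CO)c3cc(Cl)cc(Cl)c3)[C@@H]2c2ccccc2)c(C2CC2)c1`, is a single change away from compound 2: a group of 12 heavy atoms (10 carbon, 2 oxygen; one three-membered non-aromatic ring of carbon only, one six-membered aromatic ring of carbon only) in place of a group of 12 heavy atoms (8 carbon, 2 nitrogen, 2 oxygen; one five-membered aromatic ring with 2 hetero atoms, one six-membered aromatic ring of carbon only), on a saturated chain carbon bound to an amine nitrogen in a ring. The group that leaves carries the ring with two hetero atoms and two hydrogen-bond donors; the group that enters keeps the acid but offers only one donor and one acceptor.

Within the data shown here, nothing among the measured compounds isolates this exact change. Compound 1 and compound 3, which both carry a six-membered carbon ring with an acid in place of the two-hetero-atom ring, sit far above compound 2, but each also differs elsewhere. On that slim basis compound 4 is expected to need more compound than compound 2, a step of a 6.6-fold higher number from compound 2 to compound 4 (0.82 log units; beyond the scatter), with wide uncertainty. The estimate for compound 4 is 2500 nM, within a range from 400 nM to 20000 nM.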

Compound 4, half-maximal effective concentration: 1800 nM
Estimate against measurement, compound 4: 1.4-fold (0.14 log units) above, within the range that was stated.
By their numbers in this assay, from the lowest: compound 2; then compound 4; then compounds 3 and 1 (each within the scatter of the next).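

In this assay, this change now has a step of its own, a 4.7-fold higher number from compound 2 to compound 4 (0.68 log units; beyond the scatter), whereas each earlier compound differed from compound 2 in more than one place. With the rest of the molecule unchanged, the group with the five-membered aromatic ring with 2 hetero atoms gives the lower number at this position, on a saturated chain carbon bound to an amine nitrogen in a ring, and the step lies beyond the scatter. Even so, the step is modest, compound 4 still gives 1800 nM, and nothing measured here accounts for the difference between the two groups.

This single pair cannot separate the part played by the three-membered ring of carbon only from the part played by the loss of the two-hetero-atom ring, so a compound carrying an ethyl or a methoxy group in place of the three-membered ring would be informative. Going by these compounds, it also remains open whether the step would be of similar size on another core, such as that of compound 3, which carries a different ring system around the amine nitrogen.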